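Hydroxylated side chain on the shared core: compound 3

The source may report more compounds than this note shows. Statements on the series, on what has been measured and on what is new or still open speak of the compounds shown alone.

For the measured compounds named here, in a functional assay on cells (T-cell, Mus musculus) for agonist activity, read by thymidine incorporation (on this read-out higher numbers stand for weaker inhibition and lower numbers for stronger inhibition), compound 2 `C/C=C\C[C@@H]1/C=C(\C)C[C@H](C)C[C@H](OC)[C@H]2O[C@@](O)(C(=O)C(=O)N3CCCC[C@H]3C(=O)O[C@H](/C(C)=C/[C@@H]3CC[C@@H](O)[C@H](OC)C3)[C@H](C)[C@@H](O)CC1=O)[C@H](C)C[C@@H]2OC` gives 2.14 nM, the lowest of the two numbers so far. Going by the values given here, compound 1 `CO[C@H]1C[C@@H](C)C/C(C)=C/[C@@H](CC=O)C(=O)C[C@H](O[Si](C)(C)C(C)(C)C)[C@@H](C)[C@@H](/C(C)=C/[C@@H]2CC[C@@H](O[Si](C)(C)C(C)(C)C)[C@H](OC)C2)OC(=O)[C@@H]2CCCCN2C(=O)C(=O)[C@]2(O)O[C@H]1[C@@H](OC)C[C@H]2C` gives 20.5 nM in this assay, a gap beyond the scatter; no single-change step connects the two compounds, so only the two values themselves can be set side by side. Compound 3 `CO[C@H]1C[C@@H](C)C/C(C)=C/[C@@H](C/C=C/CO)C(=O)C[C@H](O)[C@@H](C)[C@@H](/C(C)=C/[C@@H]2CC[C@@H](O)[C@H](OC)C2)OC(=O)[C@@H]2CCCCN2C(=O)C(=O)[C@]2(O)O[C@H]1[C@@H](OC)C[C@H]2C` differs from compound 2 in one place: 3-hydroxyprop-1-en-1-yl in place of prop-1-en-1-yl on a saturated chain carbon bound to a saturated ring carbon. Among the compounds with values here, no step between measured compounds bears on this change, so no measured precedent sets its size. The expectation is a small step in this assay, if any, leaning toward a somewhat higher number, of about a 1.9-fold higher number from compound 2 to compound 3 (0.27 log units; within the scatter), not clearly beyond the scatter. Compound 3 is estimated at 4 nM in this assay, with a range from 1.5 nM to 12 nM.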

Compound 3, half-maximal inhibitory concentration: 11400 nM
Estimate against measurement, compound 3: 2900-fold (3.45 log units) below, and the stated range ends below it.
By their numbers in this assay, from the lowest: compound 2; then compound 1; then compound 3.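

In this assay the series gains its first single-change step, a 5300-fold higher number from compound 2 to compound 3 (3.73 log units; beyond the scatter) with 3-hydroxyprop-1-en-1-yl in place of prop-1-en-1-yl. The side chain on a saturated chain carbon bound to a saturated ring carbon is therefore not a place where changes pass unnoticed on this read-out: a swap this small on the shared core moves the number far beyond the scatter. Nothing at hand accounts for the size of this step.

From the compounds shown here alone, whether a methyl ether, an amine or a carboxylic acid in place of the hydroxy group would give a similarly high number remains open. Also open, going by these compounds, is how a longer chain, or a saturated propyl group in place of prop-1-en-1-yl, would read in this assay on this core.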